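Swapping Nitro for Methoxy on a Cytotoxic Scaffold

The source may hold more compounds than are shown below. What is called first, only, known or untested is meant among the compounds shown, and "the series" means these compounds.

Compound 1 `O=C(Nn1c(-c2cccc([N+](=O)[O-])c2)nc2c(-c3ccco3)n[nH]c2c1=O)c1cccnc1` and compound 2 `COc1cccc(-c2nc3c(-c4ccco4)n[nH]c3c(=O)n2NC(=O)c2cccnc2)c1` share one core and differ in a single spot: methoxy in place of nitro on an aromatic carbon. In a functional assay on HT-29 cells (Homo sapiens) for cytotoxicity, read by sulforhodamine B assay, with a stated time of 2 days, tested at 100 uM (on this read-out higher numbers stand for more inhibition at the one concentration tested (going by the name of the read-out) and lower numbers for less inhibition), compound 1 gives 11.7%, while compound 2 gives 12.8%, so that a number 1.1 percentage points higher from compound 1 to compound 2 (within the scatter). Compound 3 `O=C(Nn1c(-c2cccc([N+](=O)[O-])c2)nc2c(-c3ccc(Cl)cc3)n[nH]c2c1=O)c1ccccc1` rests on another core, and the difference between the two cores is not broken down here; in this assay compound 3 gives 87.8%. Compound 4 `COc1cccc(-c2nc3c(-c4ccc(Cl)cc4)n[nH]c3c(=O)n2NC(=O)c2ccccc2)c1` differs from compound 3 by methoxy in place of nitro on an aromatic carbon, the same change seen between the first pair, at the same place. Compound 4 is expected to give 82% in this assay, somewhere between 55% and 96%. Because the earlier step of a number 1.1 percentage points higher from compound 1 to compound 2 (within the scatter) lay within the scatter, the expected step of a number 5.8 percentage points lower from compound 3 to compound 4 (within the scatter) is estimated to be small too, though the new core makes this less certain.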

Compound 4, a percentage reported as inhibition, at one concentration (the size of the read-out at that concentration, not a potency): 87.3%
The estimate for compound 4 lay 5.3 percentage points below the measured number; the range from low to high includes it.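

In this assay, replacing the 3-nitrophenyl with 3-methoxyphenyl on the second core gives a number 0.5 percentage points lower from compound 3 to compound 4 (within the scatter). Set beside the first pair, the two steps agree: the same change on two cores in this assay, a number 1.1 percentage points higher (within the scatter) from compound 1 to compound 2 and a number 0.5 percentage points lower (within the scatter) from compound 3 to compound 4, 1.6 percentage points apart, within the scatter of two such steps. This shows that the change made no step larger than the scatter on either of these two cores, but two pairs cannot show that this would hold on a third core, and a reading at one concentration is not a potency.

The compounds shown leave open whether a different group at this place on the ring, such as an amine or a carboxylic acid, would also leave the reading in place. They also leave open whether the two steps would still agree at lower concentrations.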